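Swapping Methyl for Nitro in a Small Series

A few compounds are considered here, and "the series" means these few. Any claim that something is new, unique, unknown or untested is made for them only; others in the source may bear on it.

In a functional assay on HepG2 cells (Homo sapiens) for cytotoxicity, read by MTT assay, with a stated time of 48 h (a lower number here means a stronger inhibitor, a higher number a weaker inhibitor), compound 1 `O=C(/C=C\Nc1ccccc1)c1ccc2c(c1)CCCC2` gives 19.9 ug/mL, compound 2 `O=C(/C=C\Nc1ccc(Cl)cc1)c1ccc2c(c1)CCCC2` gives 30.3 ug/mL and compound 3 `Cc1ccc(N/C=C\C(=O)c2ccc3c(c2)CCCC3)cc1` gives 42.7 ug/mL. The numbers show a 2.1-fold higher number from compound 1 to compound 3 (0.33 log units; beyond the scatter), but also a 1.5-fold higher number from compound 1 to compound 2 (0.18 log units; within the scatter) and a 1.4-fold higher number from compound 2 to compound 3 (0.15 log units; within the scatter). Compound 3 therefore stands clear of compound 1 only.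

Compound 4 `O=C(/C=C\Nc1ccc([N+](=O)[O-])cc1)c1ccc2c(c1)CCCC2` carries nitro in place of methyl on an aromatic carbon. Going by the values given here, no nitro compound has been measured yet, so the guide is the three steps at this same place, and even the largest of them is only modest. No step beyond the scatter is therefore expected, and the estimated change is a 1.4-fold lower number from compound 3 to compound 4 (0.15 log units; within the scatter). For compound 4, the expected value is 30 ug/mL, with an estimated range from 14 ug/mL to 65 ug/mL.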

Compound 4, half-maximal inhibitory concentration: 27.4 ug/mL
Beside the measured number, compound 4's estimate is 1.1-fold (0.04 log units) above it, and the stated range covers the measured number.
By their numbers in this assay, from the lowest: compounds 1, 4, 2 and 3 (each within the scatter of the next, the first and the last beyond it).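

In this assay, nitro at this place gives a 1.6-fold lower number from compound 3 to compound 4 (0.19 log units; within the scatter), along with a 1.1-fold lower number from compound 2 to compound 4 (0.04 log units; within the scatter) and a 1.4-fold higher number from compound 1 to compound 4 (0.14 log units; within the scatter). So a group bringing 2 hydrogen-bond acceptors, where methyl brings none, gives no step beyond the scatter, and methyl remains the only group here that stands clear of the hydrogen of compound 1. No measurement shown explains how closely these numbers lie. Open, as far as these compounds go, is whether an amine or a carboxylic acid at this place would give a step beyond the scatter, and whether this small spread holds at other positions on the ring.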